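The compounds below may be only part of what the source reports. "The series", "measured", "known", "first", "only" and "open" are said of these compounds alone.

Measured compounds in an assay on isolated protein for inhibition of serine/threonine-protein kinase PAK 1 (Homo sapiens), read by ADP-Glo, with a stated time of 40 min; a higher number here means a weaker inhibitor, a lower number a stronger inhibitor:
- compound 1 `Cc1ccccc1C(=O)NC1CCN(c2ncnc3[nH]ncc23)CC1`: compound 1 gives 6260 nM
- compound 2 `O=C(NC1CCN(c2ncnc3[nH]ncc23)CC1)c1ccc(C(F)(F)F)cc1`: compound 2 gives 5740 nM
- compound 3 `O=C(NC1CCN(c2ncnc3[nH]ncc23)CC1)c1ccccc1Cl`: compound 3 gives 5240 nM

All three numbers sit close together. Compound 3 carries the lowest of the three, but its gaps to compound 2 and to compound 1 are both within the scatter, so no ordering among them can be read. Going by the values given here, the one measured step, a 1.2-fold lower number from compound 1 to compound 3 (0.08 log units; within the scatter), swaps a single substituent on the aromatic ring and changes nothing beyond the scatter.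

Compound 4 `Cc1ccc(NC(=O)NC2CCN(c3ncnc4[nH]ncc34)CC2)cc1` differs from compound 3 by (4-methylphenyl)amino in place of 2-chlorophenyl on a carbonyl carbon. Among the compounds with values here, this is a larger change than the one measured step: the whole 2-chlorophenyl goes and an arylamino comes in, turning the amide into a urea. Within the data shown here, no measured pair shows that kind of exchange, so the step of a 1.2-fold lower number from compound 1 to compound 3 (0.08 log units; within the scatter) bears on it only as a sign that changes at this end of the molecule have so far moved little. On that basis the step expected from compound 3 to compound 4 in this assay is a 1.0-fold higher number from compound 3 to compound 4 (0.02 log units; within the scatter), i.e. none beyond the scatter, with a wide band to reflect the untested nature of the change. Compound 4 is therefore estimated at 5500 nM, within a range of 1500 nM to 20000 nM.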

Compound 4, half-maximal inhibitory concentration: 4710 nM
Compound 4: the middle estimate sits 1.2-fold (0.07 log units) above what was measured; measured number inside the range.
By their numbers in this assay, from the lowest: compounds 4, 3, 2 and 1 (each within the scatter of the next).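

In this assay, (4-methylphenyl)amino in place of 2-chlorophenyl on the carbonyl carbon turns the amide into a urea and brings in a hydrogen-bond donor, yet the exchange gives a 1.1-fold lower number from compound 3 to compound 4 (0.05 log units; within the scatter) and stays within the scatter. Going by these compounds alone, the same exchange made against 2-methylphenyl gives a 1.3-fold lower number from compound 1 to compound 4 (0.12 log units; within the scatter), so at this position, replacing the whole aryl group and changing the linkage has moved the number no more than the single ring substituent swap did. No available evidence accounts for this flat result.

Still open, as far as these compounds go, is whether any group on this carbonyl carbon moves the number beyond the scatter, for example a piperidine amine, a carboxylic acid on the aromatic ring, or a longer alkyl chain in place of the aryl group. From the compounds shown here alone, all four compounds share one core, so the response to a change there, such as an added amine, also remains open.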